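The compounds below may be only part of what the source reports. "The series", "measured", "known", "first", "only" and "open" are said of these compounds alone.

Measured in a functional assay (trachea) with Cavia porcellus as the target; on this read-out lower numbers stand for an effect already at smaller amounts and higher numbers for an effect only at larger amounts of compound:
- compound 1 `CCCn1c(=O)n(CCC#N)c(=O)c2[nH]cnc21`: 1700 nM
- compound 2 `CCCn1c(=O)n(CCCO)c(=O)c2[nH]cnc21`: 5100 nM
- compound 3 `CCCn1c(=O)n(C)c(=O)c2[nH]cnc21`: 1600 nM

Compound 3 shares the low end of these numbers. The data show a 1.1-fold lower number from compound 1 to compound 3 (0.03 log units; within the scatter), against a 3.2-fold lower number from compound 2 to compound 3 (0.50 log units; beyond the scatter).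

Compound 4 `CCCn1c(=O)n(C)c(=O)c2c1ncn2CC#N` carries cyanomethyl in place of hydrogen on an aromatic nitrogen of a five-membered aromatic ring. Among the measured compounds shown here, no measured step touches that nitrogen, so the evidence is indirect. The closest guide is compound 1, where the same group on a saturated chain carbon gave a 1.1-fold lower number from compound 1 to compound 3 (0.03 log units; within the scatter). Only a small rise is therefore expected, with wide uncertainty. The expected step is a 1.8-fold higher number from compound 3 to compound 4 (0.24 log units; within the scatter). Compound 4 is estimated at 2800 nM, with an expected range of 900 nM to 9000 nM.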

Compound 4, half-maximal effective concentration: 35300 nM
Beside the measured number, compound 4's estimate is 13-fold (1.10 log units) below it; measured number above the stated range.
By their numbers in this assay, from the lowest: compounds 3 and 1 (each within the scatter of the next); then compound 2; then compound 4.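

In this assay, cyanomethyl on the aromatic nitrogen of the five-membered ring gives a large step (a 22-fold higher number from compound 3 to compound 4 (1.34 log units; beyond the scatter)), whereas on the saturated chain carbon bound to an aromatic nitrogen the corresponding step stays within the scatter (a 1.1-fold lower number from compound 1 to compound 3 (0.03 log units; within the scatter)). The effect of this group therefore depends strongly on where it sits. Nothing given here explains the large step at this nitrogen.

As far as these compounds go, it remains open whether an ethyl group or a longer chain ending in an amine on this nitrogen would give a similar rise, or whether the nitrile matters.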